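This account rests on a few compounds, and the source may have more. Where it says the series, first, only, none or still open, it means among the compounds named here.

Of the compounds shown here, three with a shared core have been measured so far. In an ADME assay on L02 cells (Homo sapiens) for cytotoxicity, read by MTT assay, with a stated time of 24 h (a higher number here means a weaker inhibitor, a lower number a stronger inhibitor), compound 1 `O=C1/C(=C/c2cccnc2)CNC/C1=C\c1ccccc1F` gives 15900 nM, and compound 3 `O=C1/C(=C/c2cccnc2)CN(S(=O)(=O)c2ccc(C(F)(F)F)cc2)C/C1=C\c1ccccc1F` gives 11300 nM. These two values lie within the scatter of each other, so they cannot be ranked. Compound 2 `O=C1/C(=C/c2cccnc2)CN(S(=O)(=O)c2ccc([N+](=O)[O-])cc2)C/C1=C\c1ccccc1F` gives > 20000 nM, which is a limit of the assay and not a number. Among the compounds with values here, compound 3 thus stands level with compound 1, the only other compound with a true number.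

Compound 4 `O=C1/C(=C/c2cccnc2)CN(S(=O)(=O)c2ccc(Cl)cc2)C/C1=C\c1ccccc1F` alters a single group of compound 3: chloro in place of trifluoromethyl on an aromatic carbon. Chloro takes the place of trifluoromethyl on an aromatic carbon, so 4-(trifluoromethyl)phenyl becomes 4-chlorophenyl. Within the data shown here, one measured step touches the same group, with trifluoromethyl in place of nitro: an at least 1.7-fold lower number from compound 2 to compound 3 (0.24 log units; that floor lies within the scatter). That step starts from a limit, so only its floor is known. It offers no ground for expecting a change beyond the scatter in this assay, and it favours no direction. The expectation therefore stays close to compound 3 at 11300 nM. The expected step is a 1.1-fold higher number from compound 3 to compound 4 (0.03 log units; within the scatter), which would lie within the scatter. For compound 4 the estimated value is 12000 nM, with an expected range from 6000 nM to 20000 nM.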

Compound 4, half-maximal inhibitory concentration: > 20000 nM
Compound 4: only a limit was reported (the forecaster's own chance of this, stated with the estimate: 12%); middle value at least 1.6-fold (0.22 log units) away from the limit.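

In this assay, chloro in place of trifluoromethyl on this aromatic carbon gives an at least 1.7-fold higher number from compound 3 to compound 4 (0.24 log units; that floor lies within the scatter). Compared with the unsubstituted amine, placing (4-chlorophenyl)sulfonyl on the ring nitrogen gives an at least 1.2-fold higher number from compound 1 to compound 4 (0.09 log units; that floor lies within the scatter). Both steps start from a true number and end at a limit, so only their floors are known, and neither floor goes beyond the scatter, while the step between compound 2 and compound 4 cannot be read at all. The new result does show that compound 3 is now the only one of the three arylsulfonyl compounds with a true number, and that a second group at this position has reached the same limit as nitro: the limit of > 20000 nM in this assay, at which 2 of the 4 values shown sit.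

As far as these compounds go, how far compound 2 and compound 4 lie past that limit remains unknown, so the three groups at this position cannot be put in order, and it is unclear whether trifluoromethyl really differs from chloro and nitro here. A methoxy group, an amine or a carboxylic acid on the same aromatic carbon would test whether this position can move the number at all within the range the assay can read.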